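Notes on the amine substituent, compound 3 to compound 4

The compounds below may be only part of what the source reports. "The series", "measured", "known", "first", "only" and "open" are said of these compounds alone.

Of the compounds shown here, three sharing one core have been measured. Compound 1 `COc1cc(CNCc2ccccc2)ccc1OCc1ccc(Cl)nc1` gives 90000 nM in a functional assay on HeLa cells (Homo sapiens) for inhibition, with a stated time of 72 h; on this read-out higher numbers stand for an effect only at larger amounts of compound and lower numbers for an effect already at smaller amounts. Compound 2 `COc1cc(CNCC2CCCO2)ccc1OCc1ccc(Cl)nc1` gives 66000 nM in this assay, and compound 3 `COc1cc(CNCCCN(C)C)ccc1OCc1ccc(Cl)nc1` gives 5000 nM in this assay. The move a 1.4-fold lower number from compound 1 to compound 2 (0.13 log units; within the scatter) changes little. Going by the values given here, the moves an 18-fold lower number from compound 1 to compound 3 (1.26 log units; beyond the scatter) and a 13-fold lower number from compound 2 to compound 3 (1.12 log units; beyond the scatter) are the only large steps in the set, so compound 3 stands lowest of the three, well apart from compound 2 and compound 1.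

Compound 4 `COc1cc(CNc2nc[nH]n2)ccc1OCc1ccc(Cl)nc1` is not yet measured. It differs from compound 3 by 1H-1,2,4-triazol-3-yl in place of 3-(dimethylamino)propyl on an amine nitrogen. The two informative steps both concern the same amine nitrogen: in each, the 2-(dimethylamino)ethyl group was the one that carried the low number, and its removal in favour of phenyl or oxolan-2-yl gave the high numbers of compound 1 and compound 2. Compound 4 likewise loses the 3-(dimethylamino)propyl group, and a 1H-1,2,4-triazol-3-yl enters in its place. The expected step is therefore a 12-fold higher number from compound 3 to compound 4 (1.08 log units; beyond the scatter), upward and beyond the scatter, back toward the region of compound 1 and compound 2. Compound 4 is estimated at 60000 nM in this assay, with a range from 15000 nM to 200000 nM.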

Compound 4, half-maximal effective concentration: 69000 nM
Beside the measured number, compound 4's estimate is 1.2-fold (0.06 log units) below it, within the range that was stated.
By their numbers in this assay, from the lowest: compound 3; then compounds 2, 4 and 1 (each within the scatter of the next).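

In this assay, 1H-1,2,4-triazol-3-yl in place of 3-(dimethylamino)propyl on this amine nitrogen gives a 14-fold higher number from compound 3 to compound 4 (1.14 log units; beyond the scatter), so a five-membered aromatic ring with 3 hetero atoms also ends up well apart from compound 3. The steps of a 1.0-fold higher number from compound 2 to compound 4 (0.02 log units; within the scatter) and a 1.3-fold lower number from compound 1 to compound 4 (0.12 log units; within the scatter) are both within the scatter, so the 1H-1,2,4-triazol-3-yl, (oxolan-2-yl)methyl and benzyl substituents cannot be told apart here, although they differ in ring type. Among these four compounds only compound 3 carries 3-(dimethylamino)propyl and only compound 3 stands apart with the lowest number, with no compound going against that pairing, but no supporting evidence is available to explain it.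

Still open, from the compounds shown here alone, is whether the low number of compound 3 follows the terminal dimethylamino group or the propyl chain that carries it; a terminal primary amine, a terminal hydroxyl or a longer chain ending in dimethylamino would separate the two. Also open, going by these compounds, is whether a carboxylic acid at the end of the same chain would stay with compound 3 or with the other three compounds.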